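Methyl on an Imidazole Carbon: An Expected Small Step

The source may hold more compounds than are shown below. What is called first, only, known or untested is meant among the compounds shown, and "the series" means these compounds.

Compound 1, `Cc1ncc([N+](=O)[O-])n1CCOc1ccc(F)cc1`, gives 85.8 ug/mL.
Compound 2, `Cc1cc(OCCn2c([N+](=O)[O-])cnc2C)ccc1F`, gives 116 ug/mL.
Compound 3, `Cc1ncc([N+](=O)[O-])n1CCn1ccnc1`, gives 462 ug/mL.

These values come from a functional assay on MCF7 cells (Homo sapiens) for cytotoxicity, read by MTT assay, with a stated time of 24 h; on this read-out lower numbers stand for stronger inhibition and higher numbers for weaker inhibition. Compound 2 differs from compound 1 by methyl in place of hydrogen on an aromatic carbon, and that change made a 1.4-fold higher number from compound 1 to compound 2 (0.13 log units; within the scatter). Compound 3 stands highest of the three; how its core differs from that of compound 1 is not broken down here. Compound 4, `Cc1nccn1CCn1c([N+](=O)[O-])cnc1C`, differs from compound 3 by methyl in place of hydrogen on an aromatic carbon. This is the same kind of change as that from compound 1 to compound 2, but around a different place: the earlier methyl entered on a six-membered aromatic ring of carbon only, ortho to a fluoro group and meta to a large group, whereas here it enters on a five-membered aromatic ring with 2 nitrogen, between two ring nitrogen atoms, next to the ring atom that bears a large group. Because the earlier step was a 1.4-fold higher number from compound 1 to compound 2 (0.13 log units; within the scatter), only a small step is expected for compound 4, a 1.1-fold higher number from compound 3 to compound 4 (0.05 log units; within the scatter) in this assay. Compound 4 is thus estimated at 520 ug/mL in this assay, between 250 ug/mL and 1100 ug/mL.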

Compound 4, half-maximal inhibitory concentration: 157 ug/mL
Compound 4: the middle estimate sits 3.3-fold (0.52 log units) above what was measured, outside the stated range (below it).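

In this assay, methyl in place of hydrogen on an aromatic carbon gave a 2.9-fold lower number from compound 3 to compound 4 (0.47 log units; beyond the scatter), so the step seen on the core of compound 1 did not carry over to the core of compound 3: the same change on two cores in this assay, a 1.4-fold higher number (0.13 log units; within the scatter) from compound 1 to compound 2 and a 2.9-fold lower number (0.47 log units; beyond the scatter) from compound 3 to compound 4, 4.0-fold (0.60 log units) apart, beyond the scatter of two such steps The methyl also enters a different kind of ring in each pair, so these compounds cannot separate the influence of the core from that of the place. Two pairs show that the step cannot be assumed to transfer within this series, but they give no rule for other cores and no reason for the gap.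

The compounds shown leave open how an ethyl group or an amine in the same place on compound 3 would compare. They also leave open whether a longer chain between the two ends of compound 3 would change the methyl step.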